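The source may hold more compounds than are shown below. What is called first, only, known or untested is meant among the compounds shown, and "the series" means these compounds.

Series notes, a functional assay with Alpha-1D adrenergic receptor (Homo sapiens) as the target, read by calcium flux; on this read-out lower numbers stand for smaller maximal responses and higher numbers for larger maximal responses. Compound 1 `c1cncc(-c2ccccc2OCC2=NCCN2)c1` gives 38%. Compound 2 `c1ccc(-c2ccoc2)c(OCC2=NCCN2)c1` gives 126%, the change being a number 88 percentage points higher from compound 1 to compound 2 (beyond the scatter). Compound 2 thus stands highest of the two measured numbers, with compound 1 the nearest and far lower.

Compound 3 `c1ccc(-c2ccsc2)c(OCC2=NCCN2)c1` is next, differing from compound 2 by thiophen-3-yl in place of furan-3-yl on an aromatic carbon. Going by the values given here, the one measured step, a number 88 percentage points higher from compound 1 to compound 2 (beyond the scatter), concerns a different exchange on the same position and bears only loosely here; no step from a furan-3-yl to a thiophen-3-yl has been measured. A step of a number 11 percentage points lower from compound 2 to compound 3 (beyond the scatter) is expected, lying within the scatter. Compound 3 is estimated at 115%, with a range from 85% to 145%.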

Compound 3, largest response reached (reported as maximum), in percent of the reference or control that the assay uses: 120%
Estimate against measurement, compound 3: 5 percentage points below; the measured number falls inside the stated range.
By their numbers in this assay, from the lowest: compound 1; then compounds 3 and 2 (each within the scatter of the next).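

Thiophen-3-yl and furan-3-yl are not told apart on this aromatic carbon in this assay, with a number 6 percentage points lower from compound 2 to compound 3 (within the scatter) in the scatter. The large rise over pyridin-3-yl thus recurs with a second five-membered aromatic ring, as a number 82 percentage points higher from compound 1 to compound 3 (beyond the scatter) shows, leaving compound 1 alone at the low end among these three compounds. Nothing at hand explains this difference. Open, going by these compounds, is how a plain phenyl ring or a pyridin-2-yl group would read at this place, and whether an amine or a carboxylic acid carried on the thiophen-3-yl ring would hold the response.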